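The source may hold more compounds than are shown below. What is called first, only, known or untested is meant among the compounds shown, and "the series" means these compounds.

Working notes on the series of three measured compounds and one still open.

Compound 1 `Oc1ccc(-c2cc(-c3cccc(O)c3)nc(-c3ccccc3O)c2)cc1` is measured in a functional assay on DU-145 cells (Homo sapiens) for cytotoxicity, read by CCK-8 assay, with a stated time of 4 days (a lower number here means a stronger inhibitor, a higher number a weaker inhibitor), at 3420 nM. Compound 2 `Oc1cccc(-c2cc(-c3ccccc3O)cc(-c3ccccc3O)n2)c1` gives 3980 nM in this assay. Compound 3 `Oc1ccc(-c2cc(-c3cccc(O)c3)cc(-c3cccc(O)c3)n2)cc1` returns 1940 nM in this assay, the smallest of the three numbers shown; its gap to compound 1 is within the scatter, and only its gap to compound 2 lies beyond it.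

Compound 4 `Oc1cccc(-c2cc(-c3cccc(O)c3)nc(-c3ccccc3O)c2)c1` has not yet been measured in this assay. It differs from compound 3 in one place: 2-hydroxyphenyl in place of 4-hydroxyphenyl on an aromatic carbon

For the measured compounds named here, the one measured step of the same kind is a 1.2-fold higher number from compound 1 to compound 2 (0.07 log units; within the scatter). That step, placed on the core of compound 1, moved the number by less than the scatter. The change from compound 3 to compound 4 is the same exchange of groups, though on a different arrangement of the core, so the same outcome is expected: no step beyond the scatter, with a slight lean toward a higher number in this assay because the measured step of a 1.2-fold higher number from compound 1 to compound 2 (0.07 log units; within the scatter) went that way. The step expected is a 1.2-fold higher number from compound 3 to compound 4 (0.09 log units; within the scatter). Compound 4 is therefore estimated at 2400 nM in this assay, within a range from 1200 nM to 4800 nM.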

Compound 4, half-maximal inhibitory concentration: > 50000 nM
Compound 4 gave a limit, no number; the forecaster's own chance of this, stated with the estimate: 2%; middle value at least 20-fold (1.31 log units) from the limit.
By their numbers in this assay, from the lowest: compounds 3, 1 and 2 (each within the scatter of the next, the first and the last beyond it). At a limit, above all of these: compound 4.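

In this assay compound 4 gives > 50000 nM, which is a limit of the assay and not a number. Placed on the aromatic carbon next to the ring nitrogen, meta to two 3-hydroxyphenyl groups, 2-hydroxyphenyl in place of 4-hydroxyphenyl gives an at least 25-fold higher number from compound 3 to compound 4 (1.41 log units; beyond the scatter), and the two other steps are also large, with an at least 12-fold higher number from compound 2 to compound 4 (1.09 log units; beyond the scatter) and an at least 14-fold higher number from compound 1 to compound 4 (1.16 log units; beyond the scatter), so the outcome of this exchange depends on the core that carries it: the same change on two cores in this assay, a 1.2-fold higher number (0.07 log units; within the scatter) from compound 1 to compound 2 and an at least 25-fold higher number (1.41 log units; beyond the scatter) from compound 3 to compound 4, at least 22-fold (1.34 log units) apart, beyond the scatter of two such steps. Compound 1 and compound 2 also carry 2-hydroxyphenyl and still return numbers, so the presence of that group alone does not go with the limit; the loss appears only in the full arrangement of compound 4.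

From the compounds shown here alone, the true value of compound 4 remains unknown, so the full size of all three steps remains unknown too. The compounds shown also do not tell whether the free hydroxyl of 2-hydroxyphenyl at this position is what matters, a question that a methoxy group or an amine in its place on the core of compound 4 would address.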